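A few compounds are considered here, and "the series" means these few. Any claim that something is new, unique, unknown or untested is made for them only; others in the source may bear on it.

Compounds measured so far:

- compound 1, `COc1ccc(-c2nc3cccc(-c4cc(OC)c(OC)c(OC)c4)c3o2)cc1`: 3500 nM
- compound 2, `COc1cc(-c2cccc3nc(-c4cccc(O)c4)oc23)cc(OC)c1OC`: 1900 nM
- compound 3, `COc1cc(-c2cccc3nc(-c4cccc(N)c4)oc23)cc(OC)c1OC`: 2600 nM

All three were tested in a functional assay on NCI-H460 cells (Homo sapiens) for antiproliferative activity, read by MTT assay, with a stated time of 48 h; a higher number here means a weaker inhibitor, a lower number a stronger inhibitor. Compound 1 has the highest of the three numbers; its nearest neighbour is compound 3, and the step of a 1.3-fold lower number from compound 1 to compound 3 (0.13 log units; within the scatter) lies within the scatter, as does the larger step of a 1.8-fold lower number from compound 1 to compound 2 (0.27 log units; within the scatter). Between compounds 2 and 3 the step of a 1.4-fold higher number from compound 2 to compound 3 (0.14 log units; within the scatter) is likewise within the scatter, so on these numbers the three compounds cannot be ranked.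

Compound 4, `COc1cc(-c2cccc3nc(-c4ccc5cc[nH]c5c4)oc23)cc(OC)c1OC`, has not yet been measured in this assay. It differs from compound 1 as follows: 1H-indol-6-yl in place of 4-methoxyphenyl on an aromatic carbon. The measured steps that bear on this change are the two that also replace the 4-methoxyphenyl of compound 1, a 1.8-fold lower number from compound 1 to compound 2 (0.27 log units; within the scatter) and a 1.3-fold lower number from compound 1 to compound 3 (0.13 log units; within the scatter); both brought in a hydrogen-bond donor and both moved the number down only within the scatter. The incoming 1H-indol-6-yl also carries one hydrogen-bond donor, so a small move in the same direction is expected, but nothing beyond the scatter can be asserted. The estimate therefore places compound 4 at 2500 nM, with a range from 900 nM to 7000 nM. This estimate corresponds to an expected step of a 1.4-fold lower number from compound 1 to compound 4 (0.15 log units; within the scatter).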

Compound 4, half-maximal inhibitory concentration: 24 nM
Compound 4: the middle estimate sits 100-fold (2.02 log units) above what was measured; measured number below the stated range.
By their numbers in this assay, from the lowest: compound 4; then compounds 2, 3 and 1 (each within the scatter of the next).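

Going by these compounds alone, the result shows that this place, on the five-membered aromatic ring with 1 nitrogen and 1 oxygen, next to the ring nitrogen and next to the ring oxygen, is far more sensitive to its substituent than the earlier compounds suggested: in this assay, 1H-indol-6-yl in place of 4-methoxyphenyl gives a 150-fold lower number from compound 1 to compound 4 (2.16 log units; beyond the scatter). A hydrogen-bond donor alone does not account for this, since the 3-hydroxyphenyl and 3-aminophenyl groups also carry one, yet the change from each of them to 1H-indol-6-yl is still large, with a 110-fold lower number from compound 3 to compound 4 (2.03 log units; beyond the scatter) and a 79-fold lower number from compound 2 to compound 4 (1.90 log units; beyond the scatter). Nothing available here accounts for the size of these steps in terms of any measured property of the groups.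

The compounds shown leave open whether the indole hydrogen on nitrogen is needed, which a 1-methyl-1H-indol-6-yl or a benzofuran-6-yl at the same place would test. They also leave open whether the large step depends on the rest of the shared core, since all four compounds keep it unchanged and a single methoxy group in place of its trimethoxyphenyl substituent would bear on that.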